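The compounds below may be only part of what the source reports. "The series", "measured", "known", "first", "only" and "open" are said of these compounds alone.

Measured in an ADME assay on microsomes from liver (Rattus norvegicus) for metabolic stability, with a stated time of 10 min, tested at 0.5 uM; a higher number here means that more of the compound is left, a lower number that less of the compound is left:

- compound 1 `CC(C)Cc1ccc(-c2cn(C)c3cc(C(=O)NS(C)(=O)=O)ccc23)cc1`: 94%
- compound 2 `Cn1cc(-c2ccc(C(F)(F)F)cc2)c2ccc(C(=O)NS(=O)(=O)C3CC3)cc21`: 92%
- compound 3 `Cn1cc(-c2ccc(C(F)(F)F)cc2)c2cc(F)c(C(=O)NS(C)(=O)=O)cc21`: 99%

Compound 3, at 99%, cannot be separated from the other two, since both lie within the usual scatter of it. All three compounds therefore sit close together near the top of the scale.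

The next compound to be tested is compound 4 `Cn1cc(-c2ccc(C(F)(F)F)cc2)c2ccc(C(=O)NS(C)(=O)=O)cc21`. It differs from compound 3 by one swap: hydrogen in place of fluoro on an aromatic carbon. This puts hydrogen in place of fluoro on an aromatic carbon, ortho to a (methylsulfonyl)carbamoyl group.

For the measured compounds named here, no measured pair of compounds differs in only one place, so this swap has no direct precedent here. Still, compound 1 gives 94% and compound 2 gives 92% with hydrogen on that same carbon, although they also differ elsewhere. No change beyond the scatter is therefore expected in this assay, and the estimated step is a number 5 percentage points lower from compound 3 to compound 4 (within the scatter).

For compound 4 the estimated value is 94%, with an expected range of 85% to 100%.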

Compound 4, percent of the compound remaining: 74%
For compound 4 the middle estimate is 20 percentage points above the measured one; measured number outside the range, below it.
By their numbers in this assay, from the lowest: compound 4; then compounds 2, 1 and 3 (each within the scatter of the next).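

In this assay, the swap of fluoro for hydrogen on the aromatic carbon ortho to a (methylsulfonyl)carbamoyl group now has a direct reading, and it gives a number 25 percentage points lower from compound 3 to compound 4 (beyond the scatter). Hydrogen on that carbon does not bring the lower number on its own, since the swap of cyclopropyl for methyl on the sulfonyl sulfur gives a number 18 percentage points lower from compound 2 to compound 4 (beyond the scatter), and the swap of isobutyl for trifluoromethyl on an aromatic carbon gives a number 20 percentage points lower from compound 1 to compound 4 (beyond the scatter); the low number therefore appears only with all three features together in compound 4. Nothing available explains why this combination behaves differently.

From the compounds shown here alone, whether chloro or methoxy on that aromatic carbon would hold the number up as fluoro does remains open. So does whether an ethyl group on the sulfonyl sulfur would behave like methyl or like cyclopropyl.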